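Dichlorophenyl sulfone swap on the methoxy core

This account rests on a few compounds, and the source may have more. Where it says the series, first, only, none or still open, it means among the compounds named here.

Three compounds have numbers in an assay on isolated protein for displacement of a labelled ligand from metabotropic glutamate receptor 5 (Homo sapiens), with a stated time of 60 min, tested at 1 uM; a lower number here means less inhibition, a higher number more inhibition at the concentration tested (going by the name of the read-out). Compound 1 `CC1CCN(c2c(S(=O)(=O)c3cc(Cl)cc(Cl)c3)cnc3ccc(Cl)cc23)CC1` gives 88%. Compound 2 `COc1ccc(S(=O)(=O)c2cnc3ccc(Cl)cc3c2N2CCC(C)CC2)cc1OC` gives 61%. Compound 3 `COc1ccc2ncc(S(=O)(=O)c3ccc(OC)c(OC)c3)c(N3CCC(C)CC3)c2c1` gives -3%, the lowest of the three, and its gap to either other compound is beyond the scatter.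

Two measured steps are in hand. The change 3,5-dichlorophenyl in place of 3,4-dimethoxyphenyl on a sulfonyl sulfur made a step of a number 27 percentage points higher from compound 2 to compound 1 (beyond the scatter). The change of core methoxy in place of chloro on an aromatic carbon made a step of a number 64 percentage points lower from compound 2 to compound 3 (beyond the scatter).

Compound 4 `COc1ccc2ncc(S(=O)(=O)c3cc(Cl)cc(Cl)c3)c(N3CCC(C)CC3)c2c1` is not yet measured. It differs from compound 3 by 3,5-dichlorophenyl in place of 3,4-dimethoxyphenyl on a sulfonyl sulfur, the same change as that from compound 2 to compound 1, on the same kind of place, and it occurs twice among the compounds here. The expected step for compound 4 is a number 28 percentage points higher from compound 3 to compound 4 (beyond the scatter), set beside the earlier step of a number 27 percentage points higher from compound 2 to compound 1 (beyond the scatter); this rests on that one step alone, and on compound 3 starting from -3%, where a rise of similar size is plausible but unconfirmed. Compound 4 is therefore expected to give about 25% in this assay, with a likely range from 5% to 50%.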

Compound 4, a percentage reported as inhibition, at one concentration (the size of the read-out at that concentration, not a potency): 87%
Beside the measured number, compound 4's estimate is 62 percentage points below it, and the stated range ends below it.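

In this assay, 3,5-dichlorophenyl in place of 3,4-dimethoxyphenyl on a sulfonyl sulfur gives a number 90 percentage points higher from compound 3 to compound 4 (beyond the scatter), so this change does not carry from one core to the other at a fixed size: the same change on two cores in this assay, a number 27 percentage points higher (beyond the scatter) from compound 2 to compound 1 and a number 90 percentage points higher (beyond the scatter) from compound 3 to compound 4, 63 percentage points apart, beyond the scatter of two such steps

The core change depends on the sulfonyl group in the same way, with methoxy in place of chloro on an aromatic carbon giving a number 1 percentage points lower from compound 1 to compound 4 (within the scatter): the same change on two cores in this assay, a number 64 percentage points lower (beyond the scatter) from compound 2 to compound 3 and a number 1 percentage points lower (within the scatter) from compound 1 to compound 4, 63 percentage points apart, beyond the scatter of two such steps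

This shows that the two changes do not add up across these four compounds, but it rests on a single pair of cores and a single pair of sulfonyl groups, and a read-out at one concentration does not show whether compound 1 and compound 4 match in potency.

As far as these compounds go, it remains open whether the same dependence appears with other groups on the sulfonyl sulfur, such as a pyridyl ring or a 3-chlorophenyl. From the compounds shown here alone, the core is equally open, since a nitrile or a fluoro group in place of the chloro or methoxy could behave differently.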